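The source may report more compounds than this note shows. Statements on the series, on what has been measured and on what is new or still open speak of the compounds shown alone.

In a functional assay on HCT-116 cells (Homo sapiens) for antiproliferative activity, read by MTT assay, with a stated time of 72 h (a lower number here means a stronger inhibitor, a higher number a weaker inhibitor), compound 2 (`NC1=NC2(CCOCC2)N(OCCCOc2ccc(Cl)cc2)C(N)=N1`) gives 690 nM, the highest of the three values. Compound 1 (`NC1=NC2(CCSCC2)N(OCCCOc2cccc(Cl)c2)C(N)=N1`) gives 1 nM, and compound 3 (`NC1=NC2(CCSCC2)N(OCCCOc2cccc(Cl)c2Cl)C(N)=N1`) gives 1 nM. The gap between compound 2 and each of these two compounds lies well outside the scatter.

Compound 4 (`NC1=NC2(CCOCC2)N(OCCCOc2ccc(Cl)c(Cl)c2)C(N)=N1`) keeps the core of compound 2 and replaces a hydrogen on an aromatic carbon with chloro, taking 4-chlorophenyl to 3,4-dichlorophenyl: chloro in place of hydrogen on an aromatic carbon.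

Among the compounds with values here, only one measured step is of the same kind: no change at the digits printed from compound 1 to compound 3 (within the scatter). It is weak guidance, since it sits on a different core and starts from a different chloro pattern. Going by these compounds, no chloro addition has been measured on the core of compound 2, so the size of this step there remains open. With that single precedent, no step beyond the scatter is expected in this assay, and no direction can be firmly assigned.

The estimated change is a 1.5-fold lower number from compound 2 to compound 4 (0.19 log units; within the scatter).

For compound 4 the expected value is 450 nM, with an estimated range of 100 nM to 1500 nM.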

Compound 4, half-maximal inhibitory concentration: 90 nM
Compound 4: middle estimate off by 5.0-fold (0.70 log units), on the high side; measured number below the stated range.
By their numbers in this assay, from the lowest: compounds 1 and 3 (each within the scatter of the next); then compound 4; then compound 2.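

In this assay, chloro in place of hydrogen on an aromatic carbon is not always a silent change: taking 4-chlorophenyl to 3,4-dichlorophenyl gives a 7.7-fold lower number from compound 2 to compound 4 (0.88 log units; beyond the scatter). This position, ortho to a chloro group and meta to a large group, therefore responds to the added chloro. The size of the step is not constant across the two pairs: the same change on two cores in this assay, no change at the digits printed (within the scatter) from compound 1 to compound 3 and a 7.7-fold lower number (0.88 log units; beyond the scatter) from compound 2 to compound 4, 7.7-fold (0.88 log units) apart, beyond the scatter of two such steps

The two pairs differ in both core and starting chloro pattern, and the compounds shown cannot separate these two differences. Also open, going by these compounds, is whether fluoro, methyl or methoxy at this position would give a step like that of chloro, and what 3,4-dichlorophenyl would do on the core of compound 1.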